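Dropping one methoxy from compound 3: an expected small step

The compounds below may be only part of what the source reports. "The series", "measured", "known", "first", "only" and "open" are said of these compounds alone.

Measured compounds and their values in a functional assay on the whole organism (strain albino) for inhibition, with Rattus norvegicus as the target, read by paw edema, with a stated time of 4 h, at a dose of 0.28 mmol/kg by the oral route; on this read-out lower numbers stand for less inhibition and higher numbers for more inhibition at the one dose given (going by the name of the read-out):
compound 1, `COc1ccc(-c2nnc(SC/C(=N/O)c3ccccc3)n2-c2ccccc2)cc1OC`, 81%;
compound 2, `CCn1c(SCC(=O)c2ccccc2)nnc1-c1cc(OC)c(OC)c(OC)c1`, 72%;
compound 3, `CCn1c(SC/C(=N/O)c2ccccc2)nnc1-c1cc(OC)c(OC)c(OC)c1`, 79%.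

Compound 3 stands second highest of the three in this assay: compound 1 gives 81%, compound 2 gives 72%, and both lie within the scatter of compound 3.

Compound 4, `CCn1c(SC/C(=N/O)c2ccccc2)nnc1-c1ccc(OC)c(OC)c1`, differs from compound 3 by hydrogen in place of methoxy on an aromatic carbon.

Within the data shown here, the one measured step, a number 7 percentage points higher from compound 2 to compound 3 (within the scatter), alters the sulfur-bound chain and not the methoxy-bearing ring, so it does not bear on this change. Compound 1 also carries two methoxy groups and gives 81%, within the scatter of compound 3. The expected step is therefore a number 1 percentage points lower from compound 3 to compound 4 (within the scatter), none beyond the scatter.

Compound 4 is estimated at 78%, with a range from 68% to 88%.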

Compound 4, a percentage reported as inhibition, in the whole organism at one dose (the size of the read-out at that dose, not a potency): 82%
Estimate against measurement, compound 4: 4 percentage points below; measured number inside the range.
By their numbers in this assay, from the lowest: compounds 2, 3, 1 and 4 (each within the scatter of the next).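

In this assay, hydrogen in place of methoxy on this aromatic carbon stays within the usual scatter: a number 3 percentage points higher from compound 3 to compound 4 (within the scatter). So at this one dose, this methoxy is not needed to keep the read-out. Ethyl in place of phenyl on the aromatic nitrogen, with the ring bearing the two methoxy groups unchanged, also stays within the scatter: a number 1 percentage points higher from compound 1 to compound 4 (within the scatter). No measurement at hand explains either result.

Going by these compounds, whether an amine or a carboxylic acid at this position would shift the read-out remains open. So does the effect of replacing the remaining methoxy groups.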